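Dimethylamino in place of pyridin-3-yl on porcupine

A few compounds are considered here, and "the series" means these few. Any claim that something is new, unique, unknown or untested is made for them only; others in the source may bear on it.

In an assay on L cells for inhibition of Protein-serine O-palmitoleoyltransferase porcupine (Mus musculus), read by reporter gene assay, with a stated time of 24 h (on this read-out lower numbers stand for an effect already at smaller amounts and higher numbers for an effect only at larger amounts of compound), compound 2 `O=C(CSc1nc2c(c(=O)n1-c1ccccc1)SCC2)Nc1ccc(-c2cccnc2)cc1` gives 0.45 nM, the lower of the two values in hand, while compound 1 `O=C(CSc1nc2c(c(=O)n1-c1ccccc1)SCC2)Nc1nc2ccc(Cl)cc2s1` gives 40 nM, a gap well beyond the scatter. Compound 3 `CN(C)c1ccc(NC(=O)CSc2nc3c(c(=O)n2-c2ccccc2)SCC3)cc1` arises from compound 2 by dimethylamino in place of pyridin-3-yl on an aromatic carbon. Within the data shown here, no measured pair shows this kind of exchange, so the expectation rests on compound 2 alone, and a shift toward higher numbers is expected, since a group that leaves a whole aromatic ring behind is unlikely to be matched. For compound 3 a value of 20 nM is estimated, between 3 nM and 150 nM, meaning an expected step of a 44-fold higher number from compound 2 to compound 3 (1.65 log units; beyond the scatter).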

Compound 3, half-maximal effective concentration: > 1000 nM
Compound 3 gave a limit, no number; the forecaster's own chance of this, stated with the estimate: 5%; middle value at least 50-fold (1.69 log units) away from the limit.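

In this assay compound 3 stands at a limit of the assay and not at a number: the limit of > 1000 nM in this assay, at which 1 of the 3 values shown sits. Dimethylamino in place of pyridin-3-yl gives an at least 2200-fold higher number from compound 2 to compound 3 (3.34 log units; beyond the scatter), so this carbon, para to a large group, does not tolerate every group with the same acceptor count. 4-(Dimethylamino)phenyl in place of 6-chloro-1,3-benzothiazol-2-yl on the amide-type nitrogen gives an at least 25-fold higher number from compound 1 to compound 3 (1.39 log units; beyond the scatter), so a benzene ring there does not by itself hold the value.

The compounds shown leave open whether pyridin-4-yl or unsubstituted phenyl would hold the value at this carbon, and whether a cyclic amine such as morpholine would fare better than dimethylamino.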